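The source may hold more compounds than are shown below. What is called first, only, known or untested is meant among the compounds shown, and "the series" means these compounds.

Measured so far in a functional assay (muscle tissue) with Rattus norvegicus as the target; on this read-out higher numbers stand for an effect only at larger amounts of compound and lower numbers for an effect already at smaller amounts:
- compound 1 `CNC(=O)C1=CC(C)(C)Oc2ccc([N+](=O)[O-])cc21`: 10.7 nM
- compound 2 `CCCNC(=O)C1=CC(C)(C)Oc2ccc([N+](=O)[O-])cc21`: 5.75 nM
- compound 3 `CC1(C)C=C(C(=O)NC2CC2)c2cc([N+](=O)[O-])ccc2O1`: 32.4 nM

Compound 3 has the highest number of the three. Compound 4 `CC1(C)C=C(C(=O)NCC2CC2)c2cc([N+](=O)[O-])ccc2O1` differs from it in one place: cyclopropylmethyl in place of cyclopropyl on an amide-type nitrogen. Put simply, cyclopropylmethyl stands in place of cyclopropyl on an amide-type nitrogen. Among the measured compounds shown here, two measured steps bear on this: a 3.0-fold higher number from compound 1 to compound 3 (0.48 log units; beyond the scatter) and a 5.6-fold higher number from compound 2 to compound 3 (0.75 log units; beyond the scatter). The third, a 1.9-fold lower number from compound 1 to compound 2 (0.27 log units; within the scatter), shows no clear difference between the methyl and propyl groups. Compound 4 keeps the three-membered ring, but its nitrogen carries a saturated chain carbon, as in compound 1 and compound 2. A modest move to a lower number is therefore expected, and the expected change is a 3.2-fold lower number from compound 3 to compound 4 (0.51 log units; beyond the scatter). For compound 4 the estimated value is 10 nM, with an expected range of 3.5 nM to 30 nM.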

Compound 4, half-maximal effective concentration: 6.61 nM
For compound 4 the middle estimate is 1.5-fold (0.18 log units) above the measured one; low and high end bracket the measured number.
By their numbers in this assay, from the lowest: compounds 2, 4 and 1 (each within the scatter of the next); then compound 3.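

In this assay moving the three-membered ring one saturated chain carbon away from the amide-type nitrogen lowers the number (a 4.9-fold lower number from compound 3 to compound 4 (0.69 log units; beyond the scatter)), so the high number of compound 3 does not go with the ring as such. Once that chain carbon is present, cyclopropyl on it shows no clear difference from hydrogen (a 1.6-fold lower number from compound 1 to compound 4 (0.21 log units; within the scatter)) or from ethyl (a 1.1-fold higher number from compound 2 to compound 4 (0.06 log units; within the scatter)). Nothing measured here explains these steps.

From the compounds shown here alone, whether a longer chain such as hexyl would stay in this range remains open. So does the effect of an amine or a carboxylic acid at the end of the chain.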